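The source may hold more compounds than are shown below. What is called first, only, known or untested is meant among the compounds shown, and "the series" means these compounds.

Among the compounds with values here, compound 2 `CCCn1cc(Cc2ccc(C(=O)O)cc2OC)c2cc(NC(=O)OC3CCCC3)ccc21` gives 7.72 in an assay on isolated protein (Cavia porcellus) with cysteinyl leukotriene receptor (Homo sapiens) as the target; a lower number here means a less potent compound, a higher number a more potent compound, by a factor of ten per unit of this negative logarithm; the only other number so far is compound 1 `COc1cc(C(=O)O)ccc1Cc1cn(C2CCCC2)c2ccc(NC(=O)OC3CCCC3)cc12` with 7.67, and the one recorded step, a number 0.05 log units higher from compound 1 to compound 2 (within the scatter), propyl in place of cyclopentyl on an aromatic nitrogen, lies within the scatter. Compound 3 `COc1cc(C(=O)O)ccc1Cc1cn(C)c2ccc(NC(=O)OC3CCCC3)cc12` carries hydrogen in place of ethyl on a saturated chain carbon bound to an aromatic nitrogen; the same difference cut one bond further out reads propyl to methyl. The step from compound 1 to compound 2 is the only one bearing on it, and it changed nothing beyond the scatter. The expected step in this assay is therefore a number 0.22 log units lower from compound 2 to compound 3 (within the scatter). For compound 3 the estimate is 7.5, range 7 to 8.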

Compound 3, negative logarithm of the antagonist equilibrium constant: 7.84
Estimate against measurement, compound 3: 0.34 log units below, and the stated range covers the measured number.
By their numbers in this assay, from the lowest: compounds 1, 2 and 3 (each within the scatter of the next).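

Methyl on the aromatic nitrogen sits level with propyl and cyclopentyl: a number 0.12 log units higher from compound 2 to compound 3 (within the scatter), and a number 0.17 log units higher from compound 1 to compound 3 (within the scatter). With methyl included, none of the three groups on this nitrogen separates from another beyond the scatter, so a single-carbon group here is as compatible with the number as a ring or a propyl chain. No measurement shown gives a reason for this flat result.

Still open, on these data alone, is whether hydrogen on that nitrogen, a longer chain such as octyl, or a chain ending in an amine or a carboxylic acid would move the number beyond the scatter.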